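The compounds below may be only part of what the source reports. "The series", "measured", "known", "first", "only" and "open" are said of these compounds alone.

Compound 1 `CCOC(=O)[C@H](CCC(=O)O)NC(=O)c1ccc(CNc2nc3cc(N)cc(N)c3nc2-c2ccccc2)cc1`: in a functional assay on SNB-19 cells (Homo sapiens) for inhibition, read by sulforhodamine B assay, with a stated time of 48 h (a higher number here means a weaker inhibitor of growth, a lower number a stronger inhibitor of growth), compound 1 gives < 100000 nM, a limit of the assay. Compound 2 `Nc1cc(N)c2nc(-c3ccccc3)c(NCc3ccc(Cl)c(Cl)c3)nc2c1`: in this assay compound 2 gives 51300 nM. Compound 3 `COc1ccc(CNc2nc3cc(N)cc(N)c3nc2-c2ccccc2)cc1OC`: in this assay compound 3 gives < 100000 nM, again a limit.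

Among the compounds with values here, compound 3 therefore stands only at a limit, and the step that the limit leaves unreadable from compound 2 to compound 3 cannot be sized; the one bearing piece of evidence is the limit of < 100000 nM in this assay, at which 2 of the 3 values shown sit. Compound 4 `COc1cc(CNc2nc3cc(N)cc(N)c3nc2-c2ccccc2)cc(OC)c1OC` differs from compound 3 by methoxy in place of hydrogen on an aromatic carbon. With no readable step among the measured compounds, no direction beyond the scatter is expected for an at least 1.2-fold higher number from compound 3 to compound 4 (0.07 log units; that floor lies within the scatter). Compound 4 is estimated at 120000 nM, with a range from 40000 nM to 400000 nM, most likely reported again as a limit.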

Compound 4, concentration for total growth inhibition: 20900 nM
Compound 4: the middle estimate sits 5.7-fold (0.76 log units) above what was measured, outside the stated range (below it).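

No new step can be read between compound 3 and compound 4, because compound 3 stands only at a limit: the limit of < 100000 nM in this assay, at which 2 of the 4 values shown sit. The compounds shown leave open how large a step methoxy in place of hydrogen on an aromatic carbon makes in this assay.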